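The compounds below may be only part of what the source reports. "The series", "measured", "known", "first", "only" and "open" are said of these compounds alone.

Compound 1 `N#CC1=C(N)Oc2c(c3nc4ccccc4nc3c3ccccc23)C12C(=O)N(Cc1cnnn1-c1ccc(F)cc1)c1ccccc12` carries a 4-fluorophenyl on the aromatic nitrogen of the triazole; in a functional assay on A549 cells (Homo sapiens) for antiproliferative activity, read by MTT assay, with a stated time of 48 h (a higher number here means a weaker inhibitor, a lower number a stronger inhibitor), compound 1 gives > 50000 nM, a limit of the assay rather than a number. Compound 2 `N#CC1=C(N)Oc2c(c3nc4ccccc4nc3c3ccccc23)C12C(=O)N(Cc1cnnn1-c1ccccc1Cl)c1ccccc12` has 2-chlorophenyl at that nitrogen and in this assay compound 2 gives 42600 nM. Compound 3 `N#CC1=C(N)Oc2c(c3nc4ccccc4nc3c3ccccc23)C12C(=O)N(Cc1cnnn1-c1cccc(Br)c1)c1ccccc12` carries 3-bromophenyl, and in this assay compound 3 gives > 50000 nM, again a limit and not a number. Compound 3 therefore stands at the limit, which two of the three values share (the limit of > 50000 nM in this assay, at which 2 of the 3 values shown sit). The readable steps are small: from compound 1 to compound 2 an at least 1.1-fold lower number from compound 1 to compound 2 (0.06 log units; that floor lies within the scatter), from compound 2 to compound 3 an at least 1.1-fold higher number from compound 2 to compound 3 (0.06 log units; that floor lies within the scatter), while from compound 1 to compound 3 a step that the two limits leave unreadable from compound 1 to compound 3.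

Compound 4 `CCOc1ccccc1-n1nncc1CN1C(=O)C2(C(C#N)=C(N)Oc3c2c2nc4ccccc4nc2c2ccccc32)c2ccccc21` differs from compound 3 in one place: 2-ethoxyphenyl in place of 3-bromophenyl on an aromatic nitrogen. Among the measured compounds shown here, the steps that bear on it, the exchanges of one aryl group on the same nitrogen in compounds 1, 2 and 3, all stayed within the scatter or at the limit, so no step beyond the scatter is expected in this assay in either direction. Compound 4 is expected to give about 45000 nM, between 15000 nM and 60000 nM, in this assay. The estimated step from compound 3 to compound 4 an at least 1.1-fold lower number from compound 3 to compound 4 (0.04 log units; that floor lies within the scatter) is thus expected to be negligible, with a fair chance that only a limit is reported.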

Compound 4, half-maximal inhibitory concentration: > 50000 nM
Compound 4 ended at the assay's limit; the forecaster's own chance of this, stated with the estimate: 60%; middle value at least 1.1-fold (0.04 log units) from the limit.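

Ethoxy in place of chloro on an aromatic carbon gives an at least 1.1-fold higher number from compound 2 to compound 4 (0.06 log units; that floor lies within the scatter). The steps to compound 4 from compound 1 and from compound 3 cannot be read, as both ends of each are limits. An aryl group carrying an oxygen, 2-ethoxyphenyl, on the aromatic nitrogen therefore brings no readable gain over the halogen-bearing aryl groups in this assay, and compound 2 remains the only compound with a number rather than a limit, so the series now sits largely at one limit: the limit of > 50000 nM in this assay, at which 3 of the 4 values shown sit.

From the compounds shown here alone, all four compounds carry a substituted phenyl on this nitrogen, so it remains open whether a carboxylic acid or amine on that phenyl, or a longer alkyl chain in place of the phenyl, would give a readable number in this assay. Also open, going by these compounds, is how compound 1, compound 3 and compound 4 differ from one another, as well as whether any change on this nitrogen can produce a step beyond the scatter.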